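The compounds below may be only part of what the source reports. "The series", "measured", "known", "first", "only" and "open" are said of these compounds alone.

Measured so far, in a functional assay on PBMC cells (Homo sapiens) for inhibition; on this read-out higher numbers stand for weaker inhibition and lower numbers for stronger inhibition:
compound 1, `N=C(N)NCCC[C@H](N)C(=O)NS(=O)(=O)OC[C@H]1OC[C@@H](n2cnc3c(N)ncnc32)C[C@@H]1O`: 600 nM
compound 2, `CC(C)C[C@H](N)C(=O)NS(=O)(=O)OC[C@H]1O[C@@H](n2cnc3c(N)ncnc32)[C@H](O)[C@@H]1O`: 1100 nM

Compound 2 stands with the larger of the two numbers, but its gap to compound 1 lies within the scatter, so the two compounds are not separated on this read-out. Compound 1 also carries a different amino-acid portion and a different sugar, so nothing about the amino-acid side chain alone can be read from that pair.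

Compound 3, `CC[C@H](C)[C@H](N)C(=O)NS(=O)(=O)OC[C@H]1O[C@@H](n2cnc3c(N)ncnc32)[C@H](O)[C@@H]1O`, has not yet been measured. It keeps the core of compound 2 and differs only at the amino-acid side chain: sec-butyl in place of isobutyl on a saturated chain carbon bound to an amine nitrogen and a carbonyl carbon.

Among the measured compounds shown here, no measured pair shows what this change does. The two groups match in size and count, and nothing in the two measured numbers speaks for a shift in either direction; the step is therefore expected to be no change at the digits printed from compound 2 to compound 3 (within the scatter), none beyond the scatter.

In this assay compound 3 is estimated at 1100 nM, expected to fall between 350 nM and 3500 nM.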

Compound 3, half-maximal inhibitory concentration: 5600 nM
For compound 3 the middle estimate is 5.1-fold (0.71 log units) below the measured one, and the stated range ends below it.
By their numbers in this assay, from the lowest: compounds 1 and 2 (each within the scatter of the next); then compound 3.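

In this assay, the amino-acid side chain on the core of compound 2 proves to be a position that responds to a change: sec-butyl in place of isobutyl on a saturated chain carbon bound to an amine nitrogen and a carbonyl carbon gives a 5.1-fold higher number from compound 2 to compound 3 (0.71 log units; beyond the scatter). The two groups have the same heavy-atom and carbon counts, no hydrogen-bond donors or acceptors and no net charge, so those counts do not separate them; the same atoms are joined differently, going from 1-amino-3-methylbutyl to 1-amino-2-methylbutyl, and one defined stereocentre enters. No measurement shown here offers an explanation for this step.

This single pair cannot separate the shift of the branch from the added stereocentre, and the opposite configuration of the sec-butyl group remains an open comparison. From the compounds shown here alone, compound 1 differs from compound 2 in more than one place, so how a straight butyl chain, a longer chain or a side chain bearing a carboxylic acid would read on the core of compound 2 also stays open.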